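The source may hold more compounds than are shown below. What is called first, only, known or untested is meant among the compounds shown, and "the series" means these compounds.

In an ADME assay on microsomes from liver (Canis lupus familiaris) for metabolic stability, read by LC-MS, using NADPH, with a stated time of 10 min, tested at 0.1 uM (a lower number here means slower removal, a higher number faster removal of the compound), compound 1 `COc1ccc(F)cc1N1C(=O)CSC1c1cccc(C(=O)NCCCCn2cccn2)c1` gives 480 mL.min-1.g-1, compound 2 `O=C(NCCCCn1cccn1)c1cccc(C2SCC(=O)N2c2ccccn2)c1` gives 88.9 mL.min-1.g-1 and compound 3 `Cc1ccnc(N2C(=O)CSC2c2cccc(C(=O)NCCCCn3cccn3)c2)c1` gives 41.8 mL.min-1.g-1. Compound 3 therefore has the lowest number of the three, meaning the slowest removal. Compound 4 `O=C(NCCCCn1cccn1)c1cccc(C2SCC(=O)N2c2cc(F)ccn2)c1` differs from compound 3 in a single group: fluoro in place of methyl on an aromatic carbon. Put simply, this is fluoro in place of methyl on an aromatic carbon, opposite the ring nitrogen.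

The most relevant evidence comes from this same carbon, where methyl in place of hydrogen gave a 2.1-fold lower number from compound 2 to compound 3 (0.33 log units; beyond the scatter). The larger steps, a 5.4-fold lower number from compound 1 to compound 2 (0.73 log units; beyond the scatter) and an 11-fold lower number from compound 1 to compound 3 (1.06 log units; beyond the scatter), replace the entire 5-fluoro-2-methoxyphenyl group, so they say little about this smaller change. Among the compounds with values here, no measured compound carries fluoro on this ring, so the data cannot show its effect directly. If losing the methyl gives back part of a 2.1-fold lower number from compound 2 to compound 3 (0.33 log units; beyond the scatter), a small rise would follow. The expected change is a 1.4-fold higher number from compound 3 to compound 4 (0.16 log units; within the scatter), which is a modest step at most. For compound 4 the estimated value is 60 mL.min-1.g-1, with an expected range from 28 mL.min-1.g-1 to 130 mL.min-1.g-1.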

Compound 4, intrinsic clearance in microsomes: 68.2 mL.min-1.g-1
Beside the measured number, compound 4's estimate is 1.1-fold (0.06 log units) below it; the range from low to high includes it.
By their numbers in this assay, from the lowest: compounds 3, 4 and 2 (each within the scatter of the next, the first and the last beyond it); then compound 1.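

In this assay fluoro in place of methyl gives a 1.6-fold higher number from compound 3 to compound 4 (0.21 log units; within the scatter) and fluoro in place of hydrogen gives a 1.3-fold lower number from compound 2 to compound 4 (0.12 log units; within the scatter) so on this carbon, opposite the ring nitrogen, compound 4 cannot be told apart from either of the other two, although those two differ from each other by more than the scatter. A second group besides methyl has now been seen here, and the number stays in the same low range. Placing 4-fluoropyridin-2-yl where 5-fluoro-2-methoxyphenyl stood gives a 7.0-fold lower number from compound 1 to compound 4 (0.85 log units; beyond the scatter) so the lower number now holds for all three pyridin-2-yl compounds.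

Nothing measured here explains why the numbers fall as they do. From the compounds shown here alone, whether an amine, a nitrile or a longer chain on this carbon would stay in this range remains open.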